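Changing the Pendant Aryl Ring: Expected Clearance of Compound 4

The compounds below may be only part of what the source reports. "The series", "measured", "known", "first", "only" and "open" are said of these compounds alone.

Measured compounds in an ADME assay on microsomes from liver (Homo sapiens) for metabolic stability, tested at 2.5 uM; on this read-out lower numbers stand for slow clearance and higher numbers for fast clearance:
- compound 1, `O=S(=O)(c1ccc(F)c(Cl)c1)c1cnc2cc(F)ccc2c1-c1ccc(Cl)cc1`, gives 0.39 mL/min
- compound 2, `O=S(=O)(c1cc(F)cc(F)c1)c1cnc2cc(F)ccc2c1-c1ccc(Cl)cc1`, gives 0.03 mL/min
- compound 3, `O=S(=O)(c1cc(Cl)cc(Cl)c1)c1cnc2cc(F)ccc2c1-c1ccc(Cl)cc1`, gives 0.13 mL/min

Compound 3 stands second highest of the three numbers. It sits beyond the scatter below compound 1, as a 3.0-fold lower number from compound 1 to compound 3 (0.48 log units; beyond the scatter) shows, and beyond the scatter above compound 2, as a 4.3-fold higher number from compound 2 to compound 3 (0.64 log units; beyond the scatter) shows. The widest gap in the set, a 13-fold lower number from compound 1 to compound 2 (1.11 log units; beyond the scatter), also arises from exchanging the ring on the sulfonyl sulfur.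

Compound 4, `O=S(=O)(c1cc(Cl)cc(Cl)c1)c1cnc2cc(F)ccc2c1-c1cccc(F)c1`, differs from compound 3 at a different place: 3-fluorophenyl in place of 4-chlorophenyl on an aromatic carbon. Within the data shown here, no measured step touches this ring; all three steps alter the ring on the sulfonyl sulfur, so they only show how far the numbers in this assay can move when one aryl ring replaces another, and give no direct guide to the direction here. The expectation is therefore a modest step, estimated as a 1.3-fold lower number from compound 3 to compound 4 (0.11 log units; within the scatter), carrying a wide uncertainty. Compound 4 is expected to give about 0.1 mL/min, with a plausible range from 0.04 mL/min to 0.3 mL/min.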

Compound 4, intrinsic clearance in a liver preparation (reported as CLH), per the amount of preparation that the assay uses: 0.41 mL/min
Compound 4: the middle estimate sits 4.1-fold (0.61 log units) below what was measured; measured number outside the range, above it.
By their numbers in this assay, from the lowest: compound 2; then compound 3; then compounds 1 and 4 (each within the scatter of the next).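

Within this assay, the aryl ring on the aromatic carbon opposite the ring nitrogen also affects the number, giving a 3.2-fold higher number from compound 3 to compound 4 (0.50 log units; beyond the scatter) when 3-fluorophenyl replaces 4-chlorophenyl. This step is graded modest, the same grade as a 3.0-fold lower number from compound 1 to compound 3 (0.48 log units; beyond the scatter), so in these compounds a change at this second place can matter as much as that exchange on the sulfonyl sulfur. The two groups match in their counts of heavy atoms, hydrogen-bond donors and acceptors, and in having no net charge, so those counts do not separate them, and nothing shown here explains the rise in clearance.

This single step changes both the halogen and its place on the ring, so the contribution of each remains unresolved, and the step has been read only with the 3,5-dichlorophenyl group on the sulfonyl sulfur. Also open, going by these compounds, is how the number would respond if this ring carried a different kind of group, such as an amine, a methoxy group or a carboxylic acid.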